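A few compounds are considered here, and "the series" means these few. Any claim that something is new, unique, unknown or untested is made for them only; others in the source may bear on it.

Compound 1 `C#CCCC(=O)CC1CCN(C2CCN(S(=O)(=O)c3c(C)cc(C)cc3C)CC2)CC1`: > 5000 nM
Compound 2 `Cc1cc(C)c(S(=O)(=O)N2CCC(N3CCC(O)CC3)CC2)c(C)c1`: > 5000 nM

Both entries come from an ADME assay on HCT-116 cells (Homo sapiens) for cytotoxicity, read by CellTiter-Glo, with a stated time of 72 h; a higher number here means a weaker inhibitor, a lower number a stronger inhibitor. In this assay compound 2 gives > 5000 nM, which is a limit of the assay and not a number. Compound 1 gives > 5000 nM, and this too is a limit. Compound 2 therefore has no exact place on the scale, and the firmest observation so far is the limit of > 5000 nM in this assay, at which 2 of the 2 values shown sit.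

Compound 3 `Cc1cc(C)c(S(=O)(=O)N2CCC(N3CCC(Cc4ccccc4)CC3)CC2)c(C)c1` keeps the shared core of compound 2 and differs in one place: benzyl in place of hydroxy on a saturated ring carbon. Among the measured compounds shown here, the only measured step that bears on this change is a step that the two limits leave unreadable from compound 1 to compound 2. It also swaps the hydroxy for a larger group, but it offers no size to carry forward. With no readable step as a guide, no clear shift in either direction is expected in this assay, and compound 3 will most likely be reported as a limit as well. The expected step is a step that the limit leaves unreadable from compound 2 to compound 3. For compound 3 the estimated value is 7000 nM, with an expected range from 2500 nM to 20000 nM.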

Compound 3, half-maximal inhibitory concentration: > 5000 nM
Compound 3: only a limit was reported; the forecaster's own chance of this, stated with the estimate: 75%; the middle value is on the limit's open side.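

Compound 3 gives > 5000 nM in this assay, which is a limit of the assay and not a number. The steps among compound 1, compound 2 and compound 3 therefore cannot be read, as all three stand at the same limit: the limit of > 5000 nM in this assay, at which 3 of the 3 values shown sit. Going by these compounds, what stays open is how far apart these three compounds really lie on the scale.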